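The compounds below may be only part of what the source reports. "The series", "measured", "known", "first", "only" and "open" are said of these compounds alone.

Compound 1 `Cc1cc(C(=O)N[C@H]2CCN(Cc3ccc(OCCCN(C)C)cc3)C2)ccc1Cl`: 631 nM
Compound 2 `CC(=O)N[C@H]1CCN(Cc2ccc(OCCCN(C)C)cc2)C1`: < 10000 nM

Compound 2 is known in an assay on HEK293 cells for binding affinity to Urotensin-2 receptor (Homo sapiens), read by radioligand binding (a lower number here means a stronger inhibitor, a higher number a weaker inhibitor), only as a limit, (the limit of < 10000 nM in this assay, at which 1 of the 2 values shown sits), not as a number. The change to compound 3 `CN(C)CCCOc1ccc(CN2CC[C@H](NC(=O)c3cc4ccccc4o3)C2)cc1` is 1-benzofuran-2-yl in place of methyl on a carbonyl carbon. Going by the values given here, the one measured step that touches this position, a step that the limit leaves unreadable from compound 1 to compound 2, runs the other way and is itself unreadable at the limit, so it gives no size. What remains is that compound 1, which also carries an aromatic group on that carbonyl carbon, gives 631 nM. Compound 3 is therefore expected to land near that, a step that the limit leaves unreadable from compound 2 to compound 3 whose true size the limit leaves open. The estimate for compound 3 is 500 nM, between 100 nM and 3000 nM.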

Compound 3, inhibition constant: 2510 nM
The estimate for compound 3 lay 5.0-fold (0.70 log units) below the measured number; the range from low to high includes it.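

In this assay, two aromatic groups on the carbonyl carbon can now be compared directly: 1-benzofuran-2-yl in place of 4-chloro-3-methylphenyl gives a 4.0-fold higher number from compound 1 to compound 3 (0.60 log units; beyond the scatter). An aromatic group at this position therefore does not by itself hold the number of compound 1; which aromatic group it is makes a difference. Compound 2 is known only as a limit, so the steps to and from it cannot be read: the limit of < 10000 nM in this assay, at which 1 of the 3 values shown sits.

Going by these compounds, how a plain phenyl or a pyridyl group on the carbonyl carbon would compare remains open. So does whether the chloro or the methyl of 4-chloro-3-methylphenyl contributes more to the number of compound 1.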